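Replacing 3,4-dimethoxyphenyl in compound 3

The source may hold more compounds than are shown below. What is called first, only, known or untested is meant among the compounds shown, and "the series" means these compounds.

Measured in a functional assay on DLD-1 cells (Homo sapiens) for cytotoxicity, read by MTT assay; on this read-out higher numbers stand for weaker inhibition and lower numbers for stronger inhibition
- compound 1 `COc1cc(/C=C/C(=O)C(=Cc2ccc(O)cc2)C(=O)/C=C/c2ccc(O)c(OC)c2)ccc1O` gives 4080 nM
- compound 2 `COc1cc(/C=C/C(=O)C(=Cc2ccccc2)C(=O)/C=C/c2ccc(O)c(OC)c2)ccc1O` gives 5450 nM
- compound 3 `CCOc1cc(/C=C/C(=O)C(=Cc2ccc(OC)c(OC)c2)C(=O)/C=C/c2ccc(O)c(OCC)c2)ccc1O` gives 42000 nM

Compound 3 has the highest of the three numbers. Compound 4 `CCOc1cc(/C=C/C(=O)C(=Cc2ccc(O)cc2)C(=O)/C=C/c2ccc(O)c(OCC)c2)ccc1O` is reached through (4-hydroxyphenyl in place of 3,4-dimethoxyphenyl on a double-bonded chain carbon bound to a double-bonded chain carbon), which puts 4-hydroxyphenyl in place of 3,4-dimethoxyphenyl. Within the data shown here, the one measured step, a 1.3-fold higher number from compound 1 to compound 2 (0.13 log units; within the scatter), is hydrogen in place of hydroxy and involves no 3,4-dimethoxyphenyl, so it bears only indirectly. Among the measured compounds shown here, compound 1 carries the entering 4-hydroxyphenyl and gives 4080 nM, well under compound 3, but it has methoxy where compound 4 has ethoxy, and no measured step covers that change. In this assay a lower number is expected, with the estimated 4.7-fold lower number from compound 3 to compound 4 (0.67 log units; beyond the scatter) beyond the scatter. For compound 4 the estimated value is 9000 nM, with an expected range from 3000 nM to 30000 nM.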

Compound 4, half-maximal inhibitory concentration: 20300 nM
Beside the measured number, compound 4's estimate is 2.3-fold (0.35 log units) below it; measured number inside the range.
By their numbers in this assay, from the lowest: compounds 1 and 2 (each within the scatter of the next); then compound 4; then compound 3.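

In this assay the position on a double-bonded chain carbon bound to a double-bonded chain carbon does respond to its substituent: the change gives a 2.1-fold lower number from compound 3 to compound 4 (0.32 log units; beyond the scatter) and is modest, while the earlier step, a 1.3-fold higher number from compound 1 to compound 2 (0.13 log units; within the scatter), showed no change beyond the scatter. The two steps start from different groups and carry methoxy or ethoxy on the shared core, so they cannot be set on one scale. No evidence bears on this result.

Open, on these data alone, is whether losing the methoxy groups or gaining the hydroxy carries the step. Also open, as far as these compounds go, is how 4-aminophenyl or 4-carboxyphenyl would read at this position.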